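Swapping a Furan for a Methylphenyl on the Amide

The source may report more compounds than this note shows. Statements on the series, on what has been measured and on what is new or still open speak of the compounds shown alone.

Compound 1 `NC(=O)c1c(NC(=O)c2ccco2)sc2c1CCCC2` carries a furan-2-yl on the amide carbonyl of the shared core. In a functional assay on MV4-11 cells (Homo sapiens) for antiproliferative activity (a lower number here means a stronger inhibitor, a higher number a weaker inhibitor), compound 1 gives 1500 nM. Compound 2 `CC(C)(C)c1ccc(C(=O)Nc2sc3c(c2C(N)=O)CCCC3)cc1`, with a substituted phenyl group on that carbonyl carbon, gives 1600 nM in this assay, a number within the scatter of that of compound 1, so neither stands apart. Compound 3 `Cc1cccc(C(=O)Nc2sc3c(c2C(N)=O)CCCC3)c1` differs from compound 1 by 3-methylphenyl in place of furan-2-yl on a carbonyl carbon. Because compound 2 gives 1600 nM with a phenyl-type group there, the expected step of no change at the digits printed from compound 1 to compound 3 (within the scatter) is none beyond the scatter. Compound 3 is estimated at 1500 nM, ranging from 700 nM to 3500 nM.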

Compound 3, half-maximal inhibitory concentration: 3200 nM
Compound 3: middle estimate off by 2.1-fold (0.33 log units), on the low side; measured number inside the range.
By their numbers in this assay, from the lowest: compounds 1, 2 and 3 (each within the scatter of the next, the first and the last beyond it).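

In this assay, for the compounds shown here, 3-methylphenyl in place of furan-2-yl on the carbonyl carbon gives a 2.1-fold higher number from compound 1 to compound 3 (0.33 log units; beyond the scatter), the first step at this position that lies beyond the scatter. The group held on this carbonyl can therefore shift the number, though only modestly here. No measurement shown bears on the reason for this shift. Still open, going by these compounds, is whether an aromatic ring is needed on this carbonyl at all, as a simple alkyl chain there would test. On these data alone, how an amine or a carboxylic acid on the phenyl ring would read also remains open.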